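A few compounds are considered here, and "the series" means these few. Any claim that something is new, unique, unknown or untested is made for them only; others in the source may bear on it.

Compound 1, `Brc1cccc(/N=N/N2CCCCC2)c1`: in an ADME assay on MDBK cells (Bos taurus) for cytotoxicity, read by MTT assay, with a stated time of 96 h (a lower number here means that less compound is tolerated, a higher number that more compound is tolerated), compound 1 is reported as > 100000 nM, which is a limit of the assay rather than a number.
Compound 2, `O=[N+]([O-])c1cccc(/N=N/N2CCCCC2)c1`: in this assay compound 2 is likewise reported as > 100000 nM, again a limit.
Compound 3, `FC(F)(F)c1cccc(/N=N/c2ccc(NC[C@@H]3CCCN4CCCC[C@H]34)c3c2CCCC3)c1`: in this assay compound 3 gives 30000 nM.

Among the measured compounds shown here, compound 3 thus holds the only true number here; the other two values sit at the limit of > 100000 nM in this assay, at which 2 of the 3 values shown sit. For the measured compounds named here, the single measured step, a step that the two limits leave unreadable from compound 1 to compound 2, runs between two limits and cannot be read. Compound 4, `c1ccc(/N=N/c2ccc(NC[C@@H]3CCCN4CCCC[C@H]34)c3c2CCCC3)cc1`, differs from compound 3 by hydrogen in place of trifluoromethyl on an aromatic carbon. No measured step touches a trifluoromethyl, so nothing among these compounds points in either direction, and the expectation for compound 4 is a step no larger than the usual scatter, a 1.3-fold higher number from compound 3 to compound 4 (0.12 log units; within the scatter). Compound 4 is therefore estimated at 40000 nM, with a likely range from 15000 nM to 100000 nM.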

Compound 4, half-maximal cytotoxic concentration: > 100000 nM
Compound 4: a limit, no number (the forecaster's own chance of this, stated with the estimate: 30%); middle value at least 2.5-fold (0.39 log units) away from the limit.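

Going from 3-(trifluoromethyl)phenyl to phenyl gives the first step that can be read in this assay (an at least 3.3-fold higher number from compound 3 to compound 4 (0.52 log units; beyond the scatter)). The earlier change from bromo to nitro ran between two limits and could not be read. Among the compounds shown here, compound 4 gives a limit, not a number, so this step has a known minimum but no known size, and compound 3 remains the only compound with a number: (the limit of > 100000 nM in this assay, at which 3 of the 4 values shown sit).

Going by these compounds, whether a methyl group, a chlorine atom or an amine in this place would give a number remains open. So does the true value of compound 4.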